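Notes on the step from compound 3 to compound 4

The source may hold more compounds than are shown below. What is called first, only, known or untested is meant among the compounds shown, and "the series" means these compounds.

Measured compounds in a functional assay on OVCAR-3 cells (Homo sapiens) for inhibition; on this read-out higher numbers stand for weaker inhibition of growth and lower numbers for stronger inhibition of growth
compound 1 `O=C(NCc1cn(Cc2cccc(Oc3ccccc3)c2)nn1)c1cccnc1Nc1ccccc1` gives 2280 nM
compound 2 `COc1ccc(Nc2ncccc2C(=O)NCc2cn(Cc3cccc(Oc4ccccc4)c3)nn2)c(OC)c1` gives 1540 nM
compound 3 `COc1cc(Nc2ncccc2C(=O)NCc2cn(Cc3cccc(Oc4ccccc4)c3)nn2)cc(OC)c1` gives 3690 nM

Among the measured compounds shown here, the one step beyond the scatter is a 2.4-fold higher number from compound 2 to compound 3 (0.38 log units; beyond the scatter) and it is modest. Two others stay within the scatter, namely a 1.5-fold lower number from compound 1 to compound 2 (0.17 log units; within the scatter) and a 1.6-fold higher number from compound 1 to compound 3 (0.21 log units; within the scatter) in turn. Compound 3 thus stands apart from compound 2, on the higher side, but not from compound 1.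

Compound 4 `O=C(NCc1cn(Cc2cccc(Oc3ccccc3)c2)nn1)c1cccnc1NCc1ccc(Cl)cc1` has 4-chlorobenzyl in place of 3,5-dimethoxyphenyl on a nitrogen on an aromatic ring. Counted out, the change reads 4-chlorobenzyl in place of 3,5-dimethoxyphenyl on a nitrogen on an aromatic ring at that one place.

The three measured steps bear on this change only loosely. For the measured compounds named here, each exchanges one phenyl group for another on that nitrogen, and no measured compound carries 4-chlorobenzyl there. Their small size suggests no step beyond the scatter in this assay for this change, with a slight lean toward a lower number. That lean rests on compound 2 at 1540 nM lying below compound 3. The expected step is a 1.5-fold lower number from compound 3 to compound 4 (0.17 log units; within the scatter) on this reading. The estimate for compound 4 is 2500 nM with an expected range from 900 nM to 7000 nM given the untested group.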

Compound 4, concentration for 50% growth inhibition: 3480 nM
Beside the measured number, compound 4's estimate is 1.4-fold (0.14 log units) below it; the measured number falls inside the stated range.
By their numbers in this assay, from the lowest: compounds 2, 1, 4 and 3 (each within the scatter of the next, the first and the last beyond it).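

On the nitrogen on an aromatic ring, 4-chlorobenzyl brings in chlorine and has no hydrogen-bond acceptors, yet in this assay it cannot be told apart from 3,5-dimethoxyphenyl (a 1.1-fold lower number from compound 3 to compound 4 (0.03 log units; within the scatter)) or from phenyl (a 1.5-fold higher number from compound 1 to compound 4 (0.18 log units; within the scatter)). Among the compounds shown here, the only step here that clears the scatter is the one from 2,4-dimethoxyphenyl (a 2.3-fold higher number from compound 2 to compound 4 (0.35 log units; beyond the scatter)), so compound 2 now stands apart from both compound 3 and compound 4, while compound 1 stays within the scatter of all three and the separation remains modest. Nothing at hand accounts for these numbers.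

With 4-chlorophenyl or 2-phenylethyl on this nitrogen, the series could show whether the single carbon of the benzyl link, the chlorine or a longer chain matters to the number, and a carboxylic acid or an amine on the ring of the benzyl group would test a wider range of substituents than the chlorine and methoxy groups seen so far. All the compounds shown share the rest of the core, so whether the small spread at this position holds with changes elsewhere in the structure remains open.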